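A few compounds are considered here, and "the series" means these few. Any claim that something is new, unique, unknown or untested is made for them only; others in the source may bear on it.

Series notes. Compound 1 `CC(C)n1cnc2c(Nc3cccc(-c4ncccn4)c3)nc(Cl)nc21` was run in an assay on isolated protein (Asteroidea) for inhibition of G2/mitotic-specific cyclin-B (Asterina pectinifera), read by scintillation counting and 33P incorporation, with a stated time of 30 min (a lower number here means a stronger inhibitor, a higher number a weaker inhibitor), and gives 10000 nM. Compound 2 `CC(C)n1cnc2c(Nc3cccc(-c4cncnc4)c3)nc(Cl)nc21` in this assay gives "not determined" (no result reported), so there is no number for where compound 2 stands; it carries the same chloro as compound 1. Compound 3 `CCC[C@@H](O)Nc1nc(Nc2cccc(-c3cncnc3)c2)c2ncn(C(C)C)c2n1` differs from compound 2 by a group of 6 heavy atoms (4 carbon, 1 nitrogen, 1 oxygen; no ring) in place of one chlorine atom, on an aromatic carbon. Going by the values given here, no measured pair covers this change, so the size of the step in this assay cannot be read from the data; a move toward a lower number, beyond the scatter, is expected only as a working guess. Compound 3 is expected to give about 1500 nM in this assay, within 150 nM to 10000 nM.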

Compound 3, half-maximal inhibitory concentration: 130 nM
For compound 3 the middle estimate is 12-fold (1.06 log units) above the measured one, and the stated range ends above it.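

Going by these compounds alone, no step from compound 2 to compound 3 can be read in this assay, as compound 2 has no number there. No evidence bears on the result for compound 3. From the compounds shown here alone, how much replacing the chloro changes inhibition remains open.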